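Difluoro carboxylic acid variant of a cyclohexyl aryl ether agonist

The compounds below may be only part of what the source reports. "The series", "measured", "known", "first", "only" and "open" are said of these compounds alone.

Of the compounds shown here, two have been measured in a functional assay on HEK293 cells for agonist activity at Free fatty acid receptor 1 (Homo sapiens), read by FLIPR and calcium flux; on this read-out lower numbers stand for an effect already at smaller amounts and higher numbers for an effect only at larger amounts of compound. Compound 1 `COc1ccc(F)c([C@H]2CC[C@H](COc3cccc([C@H](C4CC4)[C@H](C)C(=O)O)c3)CC2)c1` gives 0.2 nM. Compound 2 `COc1ccc(F)c([C@H]2CC[C@H](COc3cccc([C@H](C4CC4)C(C)(C)C(=O)O)c3)CC2)c1` gives 0.11 nM, the lowest of the two numbers, with compound 1 as its nearest neighbour, though the step of a 1.8-fold lower number from compound 1 to compound 2 (0.26 log units; within the scatter) lies within the scatter. Compound 3 `COc1ccc(F)c([C@H]2CC[C@H](COc3cccc([C@H](C4CC4)C(F)(F)C(=O)O)c3)CC2)c1` has not yet been measured. It differs from compound 2 by carboxy(difluoro)methyl in place of 1-carboxy-1-methylethyl on a saturated chain carbon bound to an aromatic carbon and a saturated ring carbon. Among the measured compounds shown here, only the step from compound 1 to compound 2 touches this position, and it was small; no measured step introduces fluorine in place of methyl on the carbon bearing the carboxylic acid, so the effect is open. The account expects the step of a 4.5-fold higher number from compound 2 to compound 3 (0.66 log units; beyond the scatter) to be modest, most likely toward a somewhat higher number. For compound 3 in this assay the estimate is 0.5 nM, within a range from 0.1 nM to 3 nM.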

Compound 3, half-maximal effective concentration: 16 nM
Compound 3: middle estimate off by 32-fold (1.51 log units), on the low side; measured number above the stated range.
By their numbers in this assay, from the lowest: compounds 2 and 1 (each within the scatter of the next); then compound 3.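

In this assay the saturated chain carbon bound to an aromatic carbon and a saturated ring carbon turns out to be sensitive to what carries the carboxylic acid: carboxy(difluoro)methyl in place of 1-carboxy-1-methylethyl gives a 150-fold higher number from compound 2 to compound 3 (2.16 log units; beyond the scatter) and in place of 1-carboxyethyl gives an 80-fold higher number from compound 1 to compound 3 (1.90 log units; beyond the scatter) on an otherwise shared core. The earlier step at this place stayed within the scatter, so the methyl groups alone gave no sign that two fluorines on the same carbon could move the number this far. No measurement shown here accounts for the rise.

The compounds shown leave open whether a single fluorine or a plain methylene on that carbon would track compound 3 or compound 2. They also leave open whether an ethyl group or a cyclopropane ring there would hold the low numbers.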